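From compound 3 to compound 4, at a limit

The source may hold more compounds than are shown below. What is called first, only, known or untested is meant among the compounds shown, and "the series" means these compounds.

In an ADME assay on HEK293 cells (Homo sapiens) for cytotoxicity, read by luminescence, with a stated time of 72 h (a lower number here means that less compound is needed, a higher number that more compound is needed for the effect), compound 3, `CCOC(=O)c1c(-c2cccc(Oc3c(C)cccc3C)c2)[nH]c2cc(OC)c(F)cc2c1=O`, gives > 22000 nM, which is a limit and not a number. Compound 1, `CCOC(=O)c1c(-c2cccc(OC)c2)[nH]c2cc(OC)c(F)cc2c1=O`, gives > 22000 nM, also a limit. Compound 2, `CCOC(=O)c1c(-c2cccc(Br)c2)[nH]c2cc(OC)c(F)cc2c1=O`, gives > 22000 nM, again a limit. Compound 3 thus stands with the other two, and no order among the three can be read.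

Compound 4, `CCOC(=O)c1c(-c2cccc(-c3nc(C)c(C)s3)c2)[nH]c2cc(OC)c(F)cc2c1=O`, has not yet been measured. It carries 4,5-dimethyl-1,3-thiazol-2-yl in place of 2,6-dimethylphenoxy on an aromatic carbon.

The measured steps that bear on this change alter the group on that same aromatic carbon. Replacing bromo with 2,6-dimethylphenoxy gives a step that the two limits leave unreadable from compound 2 to compound 3. Replacing methyl on the oxygen with 2,6-dimethylphenyl gives a step that the two limits leave unreadable from compound 1 to compound 3. Replacing methoxy with bromo gives a step that the two limits leave unreadable from compound 1 to compound 2. None of these has a readable size, and the three measured compounds all sit at the limit of > 22000 nM in this assay, at which 3 of the 3 values shown sit.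

With compound 3 at > 22000 nM, no step beyond the scatter and no direction can be expected for the new group. The expected change is a number no higher from compound 3 to compound 4 (the limit leaves the size open). For compound 4 the estimate is 22000 nM, with an expected range of 9000 nM to 45000 nM, and a report of only a limit is the likeliest outcome.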

Compound 4, half-maximal effective concentration: > 22000 nM
Compound 4 gave a limit, no number; the forecaster's own chance of this, stated with the estimate: 80%; the middle value sits exactly at the limit.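

Compound 4, like compound 1, compound 2 and compound 3, gives only a limit in this assay, so no step among the four can be read: the limit of > 22000 nM in this assay, at which 4 of the 4 values shown sit.

The compounds shown leave open what concentration any of them would need for the effect, and whether the group on that aromatic carbon alters it at all.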